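The source may hold more compounds than are shown below. What is called first, only, known or untested is meant among the compounds shown, and "the series" means these compounds.

Compound 1 `N=C(N)NCCC[C@H](NC(=O)[C@@H](CC1CCCCC1)NCCC(=O)O)C(=O)NCc1ccc(C(=N)N)cc1` gives 2800 nM in an assay on isolated protein for inhibition of vitamin K-dependent protein C (Homo sapiens), read by spectrophotometry, with stated times of 300 s and 40 min; on this read-out higher numbers stand for weaker inhibition and lower numbers for stronger inhibition. Compound 2 `N=C(N)c1ccc(CNC(=O)C(CCC2CCNCC2)NC(=O)[C@@H](NCC(=O)O)C2CCCCC2)cc1` returns only > 44000 nM in this assay, a limit and not a number, so that (the limit of > 44000 nM in this assay, at which 1 of the 2 values shown sits). Compound 3 `N=C(N)c1ccc(CNC(=O)C(CCC2CCNCC2)NC(=O)[C@H](N)CC2CCCCC2)cc1` differs from compound 2 by 1-amino-2-cyclohexylethyl in place of ((carboxymethyl)amino)(cyclohexyl)methyl on a carbonyl carbon, in words 1-amino-2-cyclohexylethyl in place of ((carboxymethyl)amino)(cyclohexyl)methyl on a carbonyl carbon. For the measured compounds named here, no measured step between two compounds exists here, so the expectation rests on compound 1, for which 2800 nM is a number rather than a limit. The expected step is an at least 5.5-fold lower number from compound 2 to compound 3 (0.74 log units; beyond the scatter), a gain beyond the scatter. The estimate for compound 3 is 8000 nM, with a range from 1500 nM to 40000 nM.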

Compound 3, half-maximal inhibitory concentration: 3100 nM
Compound 3: the middle estimate sits 2.6-fold (0.41 log units) above what was measured; the range from low to high includes it.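

In this assay, 1-amino-2-cyclohexylethyl in place of ((carboxymethyl)amino)(cyclohexyl)methyl on a carbonyl carbon gives an at least 14-fold lower number from compound 2 to compound 3 (1.15 log units; beyond the scatter), so this position can carry a group that gives a measurable number on this core. The size of the step is only a lower bound, and compound 2 is a limit and not a number: the limit of > 44000 nM in this assay, at which 1 of the 3 values shown sits.

The change swaps the carboxymethyl group for a plain amine and also alters the link to the cyclohexyl ring, and the compounds shown do not separate the two. Amino(cyclohexyl)methyl at this position would tell them apart.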